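Fluoro in place of methoxy in a weakly cytotoxic pair

The source may hold more compounds than are shown below. What is called first, only, known or untested is meant among the compounds shown, and "the series" means these compounds.

Measured so far in a functional assay on HL-60 cells (Homo sapiens) for cytotoxicity, read by MTT assay, with a stated time of 48 h; on this read-out lower numbers stand for stronger inhibition and higher numbers for weaker inhibition:
- Compound 1 (`Fc1cccc(-c2nc(Nc3ccccc3)c3ccccc3n2)c1`) reads > 50000 nM (a limit)
- Compound 2 (`COc1ccc(Nc2nc(-c3cccc(F)c3)nc3ccc(F)cc23)cc1`) reads 38600 nM (a number)

The entry for compound 1 is a limit of the assay and not a number (the limit of > 50000 nM in this assay, at which 1 of the 2 values shown sits). Within the data shown here, compound 2 reads 38600 nM and so holds the only actual number so far.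

Compound 3 (`Fc1ccc(Nc2nc(-c3cccc(F)c3)nc3ccc(F)cc23)cc1`) carries fluoro in place of methoxy on an aromatic carbon of compound 2, para to a large group (fluoro in place of methoxy on an aromatic carbon). Among the measured compounds shown here, no measured step in this assay shows what such a change does, so compound 2 at 38600 nM is the only anchor. A small change with no firm direction is expected, and the estimated 1.0-fold higher number from compound 2 to compound 3 (0.02 log units; within the scatter) stays within the usual scatter. Compound 3 is expected to read 40000 nM (estimated range 16000 nM to 70000 nM).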

Compound 3, half-maximal inhibitory concentration: > 50000 nM
Compound 3 was reported as a limit; the forecaster's own chance of this, stated with the estimate: 35%; middle value at least 1.2-fold (0.09 log units) from the limit.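

In this assay, fluoro in place of methoxy, para to a large group, gives an at least 1.2-fold higher number from compound 2 to compound 3 (0.11 log units; that floor lies within the scatter). Compound 3 reads > 50000 nM, which is a limit of the assay and not a number. This is the first measured change at this position: it shows that fluoro brings no stronger reading here and leaves compound 2 as the only compound shown with an actual number, while the limit now holds most of the readings: the limit of > 50000 nM in this assay, at which 2 of the 3 values shown sit.

As far as these compounds go, how far compound 3 truly lies from compound 2 stays unknown, so the size of this change cannot be stated beyond its floor. Also open, from the compounds shown here alone, is whether an amine, a carboxylic acid or a longer chain such as ethoxy at this position would give a stronger reading than methoxy.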